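Cytotoxicity notes on the alkyne series

This account rests on a few compounds, and the source may have more. Where it says the series, first, only, none or still open, it means among the compounds named here.

In an ADME assay on HepG2 cells (Homo sapiens) for cytotoxicity, read by MTT assay, with a stated time of 72 h (on this read-out higher numbers stand for lower toxicity in this test and lower numbers for higher toxicity in this test), compound 2 `O=[N+]([O-])c1c(CS(=O)(=O)c2ccccc2)nc2c(C#Cc3ccccc3F)cc(Cl)cn12` gives only a limit, > 3900 nM, and no number behind it. Compound 1 `O=[N+]([O-])c1c(CS(=O)(=O)c2ccccc2)nc2c(C#Cc3ccccc3)cc(Cl)cn12` also sits at a limit in this assay, > 3900 nM. For the measured compounds named here, compound 3 `O=[N+]([O-])c1c(CS(=O)(=O)c2ccccc2)nc2c(C#CCO)cc(Cl)cn12` is the one member with a number in this assay, 10100 nM. Because of the limit of > 3900 nM in this assay, at which 2 of the 3 values shown sit, the step that the two limits leave unreadable from compound 1 to compound 2 cannot be sized, and the same holds for a step that the limit leaves unreadable from compound 1 to compound 3 and for a step that the limit leaves unreadable from compound 2 to compound 3.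

Compound 4 `CCC(O)CC#Cc1cc(Cl)cn2c([N+](=O)[O-])c(CS(=O)(=O)c3ccccc3)nc12` differs from compound 2 as follows: 2-hydroxybutyl in place of 2-fluorophenyl on a triple-bonded carbon. Going by the values given here, the closest measured step is the one from compound 2 to compound 3, which removes the same 2-fluorophenyl from the same triple-bonded carbon and puts hydroxymethyl there; the limit leaves its size unreadable. Among the compounds with values here, the only number in hand for a compound carrying a hydroxyl-bearing chain on that carbon is therefore that of compound 3, which is the anchor for the estimate.

No readable step exists in this assay, so compound 4 is expected to land near where compound 3 stands rather than at the limit. Compound 4 is estimated at 9000 nM in this assay, within 4000 nM to 22000 nM. The step this implies, a step that the limit leaves unreadable from compound 2 to compound 4, is an expectation only and may again end at the limit.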

Compound 4, half-maximal cytotoxic concentration: > 62500 nM
Compound 4 ended at the assay's limit; the forecaster's own chance of this, stated with the estimate: 25%; middle value at least 6.9-fold (0.84 log units) from the limit.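

In this assay this position now has its first readable step, with 1-hydroxypropyl in place of hydroxy on the saturated chain carbon bound to a triple-bonded carbon: an at least 6.1-fold higher number from compound 3 to compound 4 (0.79 log units; beyond the scatter). Compound 4 gives > 62500 nM, which is a limit of the assay and not a number, so this step has only a lower bound on its size. For the compounds shown here, compound 3 and compound 4 both carry a hydroxyl-bearing chain on the triple-bonded carbon, yet the higher number for compound 4 means lower toxicity in this test, so the read-out here depends on more than the presence of such a chain, something the earlier compounds could not show.

Going by these compounds, the steps from compound 1 and from compound 2 to compound 4 cannot be read, which leaves open how the phenyl and 2-fluorophenyl groups rank against 2-hydroxybutyl: the limit of > 3900 nM in this assay, at which 2 of the 4 values shown sit. Also open is whether the rise from compound 3 to compound 4 needs the hydroxyl at all, and whether a plain butyl chain, an amine-bearing chain or a chain longer than 2-hydroxybutyl would stand with compound 3 or with compound 4.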